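The source may hold more compounds than are shown below. What is called first, only, known or untested is meant among the compounds shown, and "the series" means these compounds.

Compound 1 `COc1cc(-c2nn(-c3cccc(NC(=O)c4ccc(Cl)c(C(F)(F)F)c4)c3)cc2-c2ccncc2)ccc1Cl` was tested in a functional assay on MDA-MB-231 cells (Homo sapiens) for inhibition, read by sulforhodamine B assay, with a stated time of 48 h (on this read-out lower numbers stand for stronger inhibition of growth and higher numbers for weaker inhibition of growth), where compound 1 gives 1200 nM. Among the two compounds measured so far this is the highest number, meaning the weakest inhibition of growth. The other measured compound, compound 2 `O=C(Nc1cccc(-n2cc(-c3ccncc3)c(-c3ccc(Cl)c(O)c3)n2)c1)Nc1ccc(Cl)c(C(F)(F)F)c1`, gives 488 nM in this assay, a lower number that lies beyond the usual scatter of such measurements. For the measured compounds named here, no measured pair differs in just one place, so nothing is known directly about how a single change moves the read-out.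

Compound 3 `COc1cc(-c2nn(-c3cccc(NC(=O)Nc4ccc(Cl)c(Cl)c4)c3)cc2-c2ccncc2)ccc1Cl` has not yet been measured in this assay. It differs from compound 1 in one place: (3,4-dichlorophenyl)amino in place of 4-chloro-3-(trifluoromethyl)phenyl on a carbonyl carbon. Because compound 2, which gives 488 nM, already shows that a lower number than compound 1 is reachable in this series, compound 3 is expected to move downward by a modest step, estimated as a 2.0-fold lower number from compound 1 to compound 3 (0.30 log units; within the scatter). The number for compound 3 in this assay is estimated at 600 nM, with a likely range from 200 nM to 1800 nM.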

Compound 3, concentration for 50% growth inhibition: 698 nM
Beside the measured number, compound 3's estimate is 1.2-fold (0.07 log units) below it; the range from low to high includes it.
By their numbers in this assay, from the lowest: compounds 2, 3 and 1 (each within the scatter of the next, the first and the last beyond it).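

In this assay, for the compounds shown here, putting (3,4-dichlorophenyl)amino in place of 4-chloro-3-(trifluoromethyl)phenyl on a carbonyl carbon gives a 1.7-fold lower number from compound 1 to compound 3 (0.24 log units; within the scatter), so this is the first direct reading of a single change at this position, and the read-out does not separate the two compounds. The change adds a nitrogen that carries a hydrogen-bond donor and gives up the trifluoromethyl group for a second chlorine, yet this one step cannot show what each of those parts contributes. No independent measurement bears on how either part acts on growth inhibition.

The compounds shown leave open whether the nitrogen or the chlorine matters more when each is changed alone. They also leave open how the read-out responds on this carbonyl carbon to a cyclohexyl ring or a longer carbon chain in place of the aromatic ring.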